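The source may hold more compounds than are shown below. What is called first, only, known or untested is meant among the compounds shown, and "the series" means these compounds.

Four compounds share one core, and their growth inhibition was studied in a functional assay on DU-145 cells (Homo sapiens) for inhibition, read by trypan blue exclusion, with a stated time of 96 h; on this read-out higher numbers stand for weaker inhibition of growth and lower numbers for stronger inhibition of growth. Compound 1 `COc1ccc(S(=O)(=O)/C(=C/c2ccc(C)s2)C(=O)c2ccc(Cl)cc2)cc1` gives 25000 nM in this assay. Compound 2 `Cc1ccc(/C=C(\C(=O)c2ccc(Cl)cc2)S(=O)(=O)Cc2ccc(F)cc2)s1` gives 50000 nM in this assay. Compound 3 `Cc1ccc(/C=C(/SCc2ccc(F)cc2)C(=O)c2ccc(Cl)cc2)s1` reaches only a limit of this assay, > 100000 nM, rather than a number. Compound 4 `COc1ccc(S/C(=C/c2ccc(C)s2)C(=O)c2ccc(Cl)cc2)cc1` has not yet been measured.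

The change from compound 2 to compound 1 is 4-methoxyphenyl in place of 4-fluorobenzyl on a sulfonyl sulfur, and it made a 2.0-fold lower number from compound 2 to compound 1 (0.30 log units; within the scatter). Compound 4 arises from compound 3 by 4-methoxyphenyl in place of 4-fluorobenzyl on a sulfur. The two changes are the same kind of change, not the same: in one the place is a sulfonyl sulfur, in the other a sulfur, each with a double-bonded chain carbon as its other neighbour. How the core of compound 3 differs from that of compound 2 is not broken down here.

The earlier step lay within the scatter, so little movement is expected here either. The step of a number no higher from compound 3 to compound 4 (the limit leaves the size open) is expected to be small. Compound 4 is therefore expected to give about 100000 nM, likely between 40000 nM and 300000 nM, and may well again sit at the limit (the limit of > 100000 nM in this assay, at which 1 of the 3 values shown sits).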

Compound 4, concentration for 50% growth inhibition: 50000 nM
Compound 4: the middle estimate sits 2.0-fold (0.30 log units) above what was measured, and the stated range covers the measured number.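

Placed on a sulfur in compound 3, 4-methoxyphenyl in place of 4-fluorobenzyl gives an at least 2.0-fold lower number from compound 3 to compound 4 (0.30 log units; that floor lies within the scatter) in this assay. The value of compound 3, > 100000 nM, is a limit of the assay and not a number, so this step has a floor but no known size, and the floor itself does not rise beyond the ordinary spread of repeat measurements. The result fits with the change carrying over from the sulfonyl core to the sulfur core, but it does not show that the change has the same size on both, nor that it has a real effect on either: the same change on two cores in this assay, a 2.0-fold lower number (0.30 log units; within the scatter) from compound 2 to compound 1 and an at least 2.0-fold lower number (0.30 log units; that floor lies within the scatter) from compound 3 to compound 4; the limit leaves it open whether they differ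

The compounds shown leave open what other groups would do at this place on the sulfur or sulfonyl sulfur, such as a simple phenyl, a longer chain or a chain ending in a carboxylic acid or an amine. They also leave open whether either step would reach a clear size if the same change were read on a core giving a number at both ends.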